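Pyridyl to imidazolyl at the chain end of compound 1

The source may hold more compounds than are shown below. What is called first, only, known or untested is meant among the compounds shown, and "the series" means these compounds.

Three acylguanidines share a core and a three-carbon chain from the amine nitrogen. Compound 1 `CC(CC(=O)/N=C(\N)NCCCc1cccnc1)c1ccccc1` gives 5.27 in a functional assay on Sf9 cells for antagonist activity at histamine H2 receptor (Homo sapiens), with stated times of 2 min and 20 min (on this read-out higher numbers stand for higher potency (the scale is a negative logarithm) and lower numbers for lower potency), the lowest of the three numbers. Compound 2 `N/C(=N\C(=O)CC(c1ccccc1)c1ccccc1)NCCCc1cccnc1` gives 6.14, and compound 3 `CN(C)Cc1ccc(CCCN/C(N)=N/C(=O)CC(c2ccccc2)c2ccccc2)o1` gives 7.03. The step of a number 0.87 log units higher from compound 1 to compound 2 (beyond the scatter) comes from phenyl in place of methyl on a saturated chain carbon bound to an aromatic carbon and a saturated chain carbon. The step of a number 0.89 log units higher from compound 2 to compound 3 (beyond the scatter) comes from 5-((dimethylamino)methyl)furan-2-yl in place of pyridin-3-yl on a saturated chain carbon, three bonds along the chain from an amine nitrogen.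

Compound 4 `CC(CC(=O)/N=C(\N)NCCCn1ccnc1)c1ccccc1` differs from compound 1 by 1H-imidazol-1-yl in place of pyridin-3-yl on a saturated chain carbon, three bonds along the chain from an amine nitrogen. Among the compounds with values here, only the step from compound 2 to compound 3 touches the same place, and it shows that exchanging the ring there can move the number by a modest amount; no measured step replaces pyridin-3-yl with imidazol-1-yl, so the size and direction of this change are not fixed by the data. A small step, within or just beyond the scatter, is expected, leaning lower, estimated as a number 0.17 log units lower from compound 1 to compound 4 (within the scatter). Compound 4 is therefore expected to give about 5.1 in this assay, within 4.4 to 5.8.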

Compound 4, negative logarithm of the antagonist equilibrium constant: < 5
Compound 4 gave a limit, no number (the forecaster's own chance of this, stated with the estimate: 10%); middle value at least 0.10 log units from the limit.
By their numbers in this assay, from the lowest: compound 1; then compound 2; then compound 3. At a limit, below all of these: compound 4.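

Compound 4 stands at a limit in this assay, which is not a number: the limit of < 5 in this assay, at which 1 of the 4 values shown sits. The change to 1H-imidazol-1-yl in place of pyridin-3-yl can therefore be read only as a floor, a number at least 0.27 log units lower from compound 1 to compound 4 (that floor lies within the scatter), so the data do not settle whether the full step lies beyond the scatter. The only earlier exchange of the ring at this place on a saturated chain carbon, three bonds along the chain from an amine nitrogen, went the other way, a number 0.89 log units higher from compound 2 to compound 3 (beyond the scatter), so this place is now shown to take one ring exchange with a higher number and another with no rise, though the two steps start from compounds that differ by phenyl in place of methyl.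

The compounds shown leave open whether 1H-imidazol-1-yl and 5-((dimethylamino)methyl)furan-2-yl would keep this contrast if both stood on one shared core, since neither pair of steps can be read on the same background. Also open, going by these compounds, is how this place responds to a primary amine at the chain end, or to a longer chain carrying 1H-imidazol-1-yl.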